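This account rests on a few compounds, and the source may have more. Where it says the series, first, only, none or still open, it means among the compounds named here.

Of the compounds shown here, two have so far been measured in an assay on HeLa cells for displacement of a labelled ligand from 5-hydroxytryptamine receptor 6 (Homo sapiens), with a stated time of 2 h; a higher number here means a weaker inhibitor, a lower number a stronger inhibitor. Compound 1 `O=S(=O)(c1cccc(F)c1)c1cn(C2CCNC2)c2cc(Cl)ccc12` gives 72 nM in this assay, the lowest of the two numbers, yet the gap to compound 2 lies within the scatter, so the two are not told apart. Compound 2 `O=S(=O)(c1ccccc1)c1cn(C2CCNCC2)c2ccccc12` gives 91 nM in this assay. Among the compounds with values here, no two measured compounds differ in only one place, so no single step is known from the data. Compound 3 `O=S(=O)(c1cccc(F)c1)c1cn(C2CCNC2)c2ccccc12` has not yet been measured in this assay. It differs from compound 1 in one place: hydrogen in place of chloro on an aromatic carbon. Within the data shown here, with no measured step of this kind to lean on, the expectation rests on compound 1 alone, and a modest weakening is expected, expressed as the step of a 2.1-fold higher number from compound 1 to compound 3 (0.32 log units; beyond the scatter), though a change no larger than the scatter would not surprise. Compound 3 is therefore expected to give about 150 nM in this assay, most likely between 50 nM and 450 nM.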

Compound 3, inhibition constant: 4.7 nM
Beside the measured number, compound 3's estimate is 32-fold (1.50 log units) above it; the measured number lies below the stated range.
By their numbers in this assay, from the lowest: compound 3; then compounds 1 and 2 (each within the scatter of the next).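

In this assay hydrogen in place of chloro on this aromatic carbon, part of a fused system of two rings, gives a 15-fold lower number from compound 1 to compound 3 (1.19 log units; beyond the scatter) and so counts as a large step. A single heavy atom at this one position therefore weighs heavily on the binding number, and in this pair the chloro group comes at a clear cost rather than sitting there with no effect. Nothing measured here explains why the step is so large.

As far as these compounds go, whether only chloro carries this cost, or whether a group such as methyl or methoxy on the same carbon would carry it too, remains open. Also open, from the compounds shown here alone, is whether chloro at this position would cost as much on a different core, such as that of compound 2.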